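Lengthening the Chain on the Ring Amine

The source may report more compounds than this note shows. Statements on the series, on what has been measured and on what is new or still open speak of the compounds shown alone.

The measured compounds so far:
compound 1 `Cc1ccc(C2=CCc3ccccc3N=C2N2CCN(C)CC2)cc1`; in a functional assay on the whole organism for inhibition, with Mus musculus as the target, at a dose of 100 mg/kg by the oral route (a higher number here means more inhibition at the dose given (going by the name of the read-out), a lower number less inhibition), compound 1 gives 31%
compound 2 `CCCN1CCN(C2=Nc3ccc(CC)cc3CC=C2c2ccccc2)CC1`; in this assay compound 2 gives 31%

Compound 2 stands level with compound 1 at the digits given: the two values lie within the scatter of each other, so neither number can be called the higher of the pair. The compound not yet measured is compound 3 `CCCCN1CCN(C2=Nc3ccc(CC)cc3CC=C2c2ccccc2)CC1`. It differs from compound 2 in a single place: methyl in place of hydrogen on a saturated chain carbon, three bonds along the chain from an amine nitrogen in a ring. Within the data shown here, no measured pair shows what a change of this kind does in this assay, so the two values known here give no guide to its direction. With nothing pointing either way, the step expected in this assay is no change at the digits printed from compound 2 to compound 3 (within the scatter), which is no more than the scatter. Compound 3 is therefore expected to give 31%, in a range from 15% to 47%.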

Compound 3, a percentage reported as inhibition, in the whole organism at one dose (the size of the read-out at that dose, not a potency): 31%
Compound 3: middle estimate and measured number agree at the digits printed, and the stated range covers the measured number.
By their numbers in this assay, from the lowest: compounds 1, 2 and 3 (each within the scatter of the next).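

Among these compounds, the step from propyl to butyl on the amine nitrogen in the ring gives, in this assay, no change at the digits printed from compound 2 to compound 3 (within the scatter), the first reading of a single change. At this one oral dose, the chain on that nitrogen therefore takes one more methyl at its end with no visible effect on the read-out. Nothing here accounts for this result, and no measurement bears on why the read-out holds level.

From the compounds shown here alone, whether a longer chain such as hexyl, a branched chain such as isopropyl, or a chain ending in a hydroxyl group or a carboxylic acid would also stay level remains open. Because the read-out reports the effect at one dose rather than a potency, a single step also leaves open whether compound 2 and compound 3 would still match at other doses.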